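The compounds below may be only part of what the source reports. "The series", "measured", "known", "first", "only" and "open" are said of these compounds alone.

In an ADME assay on MT4 cells (Homo sapiens) for cytotoxicity, read by MTT assay, with a stated time of 4 days (on this read-out lower numbers stand for higher toxicity in this test and higher numbers for lower toxicity in this test), compound 1 `CC(=O)Nc1ccc(O)c(C(=O)/C=C/c2ccccc2)c1` gives 49400 nM and compound 2 `COc1cccc(/C=C/C(=O)c2cc(NC(C)=O)ccc2O)c1` gives 40000 nM. The change between them, (methoxy in place of hydrogen on an aromatic carbon), produced a 1.2-fold lower number from compound 1 to compound 2 (0.09 log units; within the scatter). Compound 3 `COc1c(-c2ccccc2)oc2ccc(NC(C)=O)cc2c1=O` gives 200000 nM, the highest of the three numbers; the difference between its core and the core of compound 1 is not broken down here. Compound 4 `COc1ccccc1-c1oc2ccc(NC(C)=O)cc2c(=O)c1OC` has not yet been measured. For the measured compounds named here, it differs from compound 3 by methoxy in place of hydrogen on an aromatic carbon, the same kind of change as the one from compound 1 to compound 2, though there the methoxy is meta to a large group and here it is ortho to a large group. Because the earlier step was a 1.2-fold lower number from compound 1 to compound 2 (0.09 log units; within the scatter), compound 4 is expected to show a step of a 1.3-fold lower number from compound 3 to compound 4 (0.10 log units; within the scatter). Compound 4 is therefore estimated at 160000 nM, between 80000 nM and 300000 nM.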

Compound 4, half-maximal cytotoxic concentration: 154000 nM
The estimate for compound 4 lay 1.0-fold (0.02 log units) above the measured number, within the range that was stated.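

In this assay, methoxy in place of hydrogen on an aromatic carbon gave a 1.3-fold lower number from compound 3 to compound 4 (0.11 log units; within the scatter), and the two cores agree on the size of this change: the same change on two cores in this assay, a 1.2-fold lower number (0.09 log units; within the scatter) from compound 1 to compound 2 and a 1.3-fold lower number (0.11 log units; within the scatter) from compound 3 to compound 4, 1.1-fold (0.02 log units) apart, within the scatter of two such steps. For the compounds shown here, both steps lie within the scatter, so the pair shows only that this change left the number essentially unmoved on both cores, not that it has a real effect that carries from one core to the other. Two cores in one assay, with the methoxy placed differently on each, also do not show that the result would hold on further cores.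

The compounds shown leave open whether a group other than methoxy, such as an amine, a carboxylic acid or a longer alkoxy chain, would shift the number beyond the scatter. They also leave open what such groups would do on either core.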